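The source may hold more compounds than are shown below. What is called first, only, known or untested is meant among the compounds shown, and "the series" means these compounds.

Measured so far in a functional assay on A549 cells (Homo sapiens) for antiproliferative activity, read by MTT assay, with a stated time of 48 h; on this read-out higher numbers stand for weaker inhibition and lower numbers for stronger inhibition:
compound 1 `COc1ccc(-c2cc3c(cn2)[nH]c(=O)n3-c2cc(OC)c(OC)c(OC)c2)cc1` — 1120 nM
compound 2 `COc1ccc(-c2cc3c(cn2)[nH]c(=O)n3-c2cc(OC)c(OC)c(OC)c2)cc1O` — 630 nM
compound 3 `CCOc1ccc(-c2cc3c(cn2)[nH]c(=O)n3-c2cc(OC)c(OC)c(OC)c2)cc1` — 5300 nM

Compound 3 gives the highest number of the three; its separations from compound 1, a 4.7-fold higher number from compound 1 to compound 3 (0.68 log units; beyond the scatter), and from compound 2, an 8.4-fold higher number from compound 2 to compound 3 (0.92 log units; beyond the scatter), both lie beyond the scatter. Compound 4 `COc1ccc(-c2cc3c(cn2)[nH]c(=O)n3-c2cc(OC)c(OC)c(OC)c2)cc1N` carries 3-amino-4-methoxyphenyl in place of 4-ethoxyphenyl on an aromatic carbon. Among the compounds with values here, two measured steps bear on this. The step of an 8.4-fold higher number from compound 2 to compound 3 (0.92 log units; beyond the scatter) covers nearly the same exchange in the opposite direction, and the step of a 1.8-fold lower number from compound 1 to compound 2 (0.25 log units; within the scatter) shows that hydroxy in place of hydrogen stays within the scatter. A return to roughly the level of compound 2 is therefore expected, and compound 4 is expected to show the step of a 7.6-fold lower number from compound 3 to compound 4 (0.88 log units; beyond the scatter). Compound 4 is estimated at 700 nM, with a range from 300 nM to 1600 nM.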

Compound 4, half-maximal inhibitory concentration: 1140 nM
For compound 4 the middle estimate is 1.6-fold (0.21 log units) below the measured one, and the stated range covers the measured number.
By their numbers in this assay, from the lowest: compounds 2, 1 and 4 (each within the scatter of the next); then compound 3.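

In this assay, amino in place of hydrogen (a 1.0-fold higher number from compound 1 to compound 4 (0.01 log units; within the scatter)) and amino in place of hydroxy (a 1.8-fold higher number from compound 2 to compound 4 (0.26 log units; within the scatter)) are not resolved, so hydrogen, hydroxy and amino cannot be told apart at this place. Among the four compounds, only the 4-ethoxyphenyl of compound 3 stands apart, and adding the amino while returning to methoxy recovers a 4.6-fold lower number from compound 3 to compound 4 (0.67 log units; beyond the scatter). Nothing available accounts for these differences.

Open: whether a carboxylic acid or dimethylamino group at this place would also stay within the scatter of compound 4, and whether ethoxy in place of the methoxy of compound 4 would repeat a 4.7-fold higher number from compound 1 to compound 3 (0.68 log units; beyond the scatter).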